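A few compounds are considered here, and "the series" means these few. Any claim that something is new, unique, unknown or untested is made for them only; others in the source may bear on it.

In a functional assay on HEL cells (Homo sapiens) (on this read-out higher numbers stand for lower toxicity in this test and lower numbers for higher toxicity in this test), three compounds that share one core and differ in the length of one chain have been measured. Compound 3 `CCCCCc1cc2cn(COCCO)c(=O)nc2o1` gives > 200000 nM, which is a limit and not a number. Compound 2 `CCCCCCCCCc1cc2cn(COCCO)c(=O)nc2o1` gives >= 100000 nM, which is also a limit. Among the compounds with values here, compound 1 `CCCCCCCc1cc2cn(COCCO)c(=O)nc2o1` gives 140000 nM, the only exact value in the set.

Compound 4 `CCCCCCCCCCc1cc2cn(COCCO)c(=O)nc2o1` is built from compound 3 by pentyl in place of hydrogen on a saturated chain carbon, five bonds along the chain from an aromatic carbon. The closest measured change on this chain is a step that the two limits leave unreadable from compound 2 to compound 3, and the next is a step that the limit leaves unreadable from compound 1 to compound 2. Within the data shown here, only one measured step has any readable size, namely an at least 1.4-fold higher number from compound 1 to compound 3 (0.15 log units; that floor lies within the scatter). The data therefore show no step beyond the scatter, and compound 1, at 140000 nM, remains the only firm anchor. In this assay a modest move toward a lower number is expected, and a large one is not. The expected change is an at least 2.2-fold lower number from compound 3 to compound 4 (0.34 log units; beyond the scatter). For compound 4 the estimated value is 90000 nM, with an expected range from 35000 nM to 200000 nM.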

Compound 4, half-maximal cytotoxic concentration: > 200000 nM
Compound 4 was reported as a limit; the forecaster's own chance of this, stated with the estimate: 45%; middle value at least 2.2-fold (0.34 log units) from the limit.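

In this assay compound 4 gives > 200000 nM, which is a limit, and with pentyl in place of hydrogen at this place on the chain the read-out still yields no exact number. Within the data shown here, the only readable step is an at least 1.4-fold higher number from compound 1 to compound 4 (0.15 log units; that floor lies within the scatter), and this longest chain therefore adds no step beyond the scatter. The steps to compound 4 from compound 3 and from compound 2 cannot be read, because each of them joins two limits: the limit of > 200000 nM in this assay, at which 2 of the 4 values shown sit.

The compounds shown leave open where, if anywhere, toxicity in this assay would rise along this series, since only compound 1 carries an exact number. They also leave open whether a longer chain, or an amine or a carboxylic acid at the chain end, would give an exact value.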